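Swapping the Amide Linker for a Sulfonamide

The compounds below may be only part of what the source reports. "The series", "measured", "known", "first", "only" and "open" are said of these compounds alone.

Compound 1 `CNc1nc2ccccc2c(NCc2ccc(NC(=O)c3ccc(F)cc3)cc2)c1C#N`: in a functional assay on SW480 cells (Homo sapiens) for inhibition, read by luminescence and resazurin assay, with a stated time of 3 days (on this read-out higher numbers stand for weaker inhibition and lower numbers for stronger inhibition), compound 1 gives > 20000 nM, a limit of the assay.
Compound 2 `CNc1nc(NCc2ccc(NC(=O)c3ccncc3)cc2)c2ccccc2n1`: in this assay compound 2 gives > 20000 nM, likewise a limit.
Compound 3 `CN(C)c1nc(NCc2ccc(NC(=O)c3ccncc3)cc2)c2ccccc2n1`: in this assay compound 3 gives 11000 nM.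

Compound 2 thus stands at the assay limit, as noted in the limit of > 20000 nM in this assay, at which 2 of the 3 values shown sit. Within the data shown here, the one measured step, an at least 1.8-fold lower number from compound 2 to compound 3 (0.25 log units; that floor lies within the scatter), concerns a methyl on a nitrogen and not the amide portion. Compound 4 `CNc1nc(NCc2ccc(NS(=O)(=O)c3ccc(F)cc3)cc2)c2ccccc2n1` arises from compound 2 through ((4-fluorophenyl)sulfonyl in place of (pyridin-4-yl)carbonyl on a nitrogen on an aromatic ring). Among the measured compounds shown here, no measured step bears on this exchange, so no shift beyond the scatter is expected. Compound 4 is accordingly expected to stay near the limit, estimated at 20000 nM with a range from 7000 nM to 60000 nM. The step this estimate implies, a number no higher from compound 2 to compound 4 (the limit leaves the size open), is expected to be no more than the scatter.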

Compound 4, half-maximal inhibitory concentration: 4800 nM
Beside the measured number, compound 4's estimate is 4.2-fold (0.62 log units) above it; the whole stated range lies above it.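

At this place, on a nitrogen on an aromatic ring, (4-fluorophenyl)sulfonyl in place of (pyridin-4-yl)carbonyl gives an at least 4.1-fold lower number from compound 2 to compound 4 (0.61 log units; beyond the scatter) in this assay. Unlike the methyl step, this is a step beyond the scatter, so the group on this nitrogen does bear on the read-out. Its full size stays unknown because compound 2 sits at a limit: the limit of > 20000 nM in this assay, at which 2 of the 4 values shown sit.

The sulfonyl and the aromatic ring change together here, and the compounds shown do not separate the two. From the compounds shown here alone, whether (pyridin-4-yl)sulfonyl or a small methanesulfonyl group on this nitrogen would keep the lower number remains open.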